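A few compounds are considered here, and "the series" means these few. Any claim that something is new, unique, unknown or untested is made for them only; others in the source may bear on it.

Of the compounds shown here, three sharing one core have been measured in a functional assay on Jurkat cells for inhibition of nuclear factor NF-kappa-B complex (Homo sapiens); a higher number here means a weaker inhibitor, a lower number a stronger inhibitor. Compound 1 `CCOC(=O)c1cnc(CC)nc1NN1C(=O)C=C(C)C1=O` carries an ethyl group on an aromatic carbon of the core and gives 10000 nM. Compound 2 `CCOC(=O)c1cnc(SC)nc1NN1C(=O)C=C(C)C1=O`, with methylsulfanyl at that carbon, gives 200 nM, a change of a 50-fold lower number from compound 1 to compound 2 (1.70 log units; beyond the scatter). Compound 3 `CCOC(=O)c1cnc(-c2ccccc2)nc1NN1C(=O)C=C(C)C1=O`, with phenyl there, gives 100 nM, a change of a 100-fold lower number from compound 1 to compound 3 (2.00 log units; beyond the scatter) from compound 1, while the step of a 2.0-fold lower number from compound 2 to compound 3 (0.30 log units; within the scatter) is small. Compound 3 thus has the lowest number of the three, but only compound 1 is separated from it beyond the scatter.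

Compound 4 `CCOC(=O)c1cnc(-c2cccs2)nc1NN1C(=O)C=C(C)C1=O` differs from compound 3 by thiophen-2-yl in place of phenyl on an aromatic carbon. The step that bears on this most directly is a 2.0-fold lower number from compound 2 to compound 3 (0.30 log units; within the scatter), where swapping one group for another at this carbon changed little, in contrast to the large steps from compound 1. Since an aromatic ring remains at this position, the step of a 1.3-fold higher number from compound 3 to compound 4 (0.11 log units; within the scatter) is expected to stay within the scatter. Compound 4 is therefore estimated at about 130 nM, with a range from 50 nM to 350 nM.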

Compound 4, half-maximal inhibitory concentration: 20 nM
Estimate against measurement, compound 4: 6.5-fold (0.81 log units) above, outside the stated range (below it).
By their numbers in this assay, from the lowest: compound 4; then compounds 3 and 2 (each within the scatter of the next); then compound 1.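

At this carbon, which lies between two ring nitrogen atoms, one aromatic ring cannot simply stand in for another: replacing phenyl with thiophen-2-yl gives a clear change (a 5.0-fold lower number from compound 3 to compound 4 (0.70 log units; beyond the scatter)), so the small step between methylsulfanyl and phenyl did not mean that the position had stopped responding. Thiophen-2-yl also stands clear of the other two groups (a 10-fold lower number from compound 2 to compound 4 (1.00 log units; beyond the scatter); a 500-fold lower number from compound 1 to compound 4 (2.70 log units; beyond the scatter)), which makes compound 4 the strongest inhibitor of the four in this assay. Nothing available here explains why this ring gives the lower number.

Still open, from the compounds shown here alone, is whether the sulfur or the five-membered ring carries the gain, a question that a furan-2-yl or thiophen-3-yl group at this carbon would help to separate. Also open, going by these compounds, is how an amine at this carbon, or a carboxylic acid in place of the ethoxycarbonyl group, would fare.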